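The same isopropyl change, carried onto a larger core

The compounds below may be only part of what the source reports. "The series", "measured", "known", "first", "only" and "open" are said of these compounds alone.

Measured compounds:
- compound 1, `CC(C)(C)C1=CC(=O)C=C(NCC(=O)O)C1=O`: in a functional assay on A549 cells (Homo sapiens) for cytotoxicity, read by MTT assay, with a stated time of 72 h (a lower number here means a stronger inhibitor, a higher number a weaker inhibitor), compound 1 reaches only the limit > 200000 nM.
- compound 3, `CC(C)[C@@H](NC1=CC(=O)C=C(C(C)(C)C)C1=O)C(=O)O`: in this assay compound 3 gives 154000 nM.
- compound 2, `CC1=CCC[C@H]2[C@](C)(CC3=CC(=O)C=C(NCC(=O)O)C3=O)[C@@H](C)CC[C@]12C`: in this assay compound 2 gives 46700 nM.

Compound 3 arises from compound 1 by one change, (isopropyl in place of hydrogen on a saturated chain carbon bound to an amine nitrogen and a carbonyl carbon). Since compound 1 sits at a limit, the step can only be given a floor: an at least 1.2-fold lower number from compound 1 to compound 3 (0.11 log units; that floor lies within the scatter). Compound 2 carries a different core; the difference between the two cores is not broken down here. Compound 2 has the lowest of the two numbers, and compound 3 stands nearest to it.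

Compound 4, `CC1=CCC[C@H]2[C@](C)(CC3=CC(=O)C=C(N[C@@H](C(=O)O)C(C)C)C3=O)[C@@H](C)CC[C@]12C`, is not yet measured. It differs from compound 2 by isopropyl in place of hydrogen on a saturated chain carbon bound to an amine nitrogen and a carbonyl carbon, the same change as between compound 1 and compound 3, at the same place. Because that first step rests on a limit (the limit of > 200000 nM in this assay, at which 1 of the 3 values shown sits), it gives little guidance beyond its floor. The step from compound 2 to compound 4 in this assay is therefore expected to be modest, a 1.6-fold lower number from compound 2 to compound 4 (0.19 log units; within the scatter). For compound 4 the estimate is 30000 nM, with a range from 12000 nM to 80000 nM.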

Compound 4, half-maximal inhibitory concentration: 23800 nM
Beside the measured number, compound 4's estimate is 1.3-fold (0.10 log units) above it, within the range that was stated.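

Replacing hydrogen with isopropyl on the larger core gives a 2.0-fold lower number from compound 2 to compound 4 (0.29 log units; within the scatter), so in this assay this pair cannot be told apart from repeat measurements of a single compound. Set beside the same change on the core of compound 1, the result does not settle whether the change carries over from one core to the other with the same size: the same change on two cores in this assay, an at least 1.2-fold lower number (0.11 log units; that floor lies within the scatter) from compound 1 to compound 3 and a 2.0-fold lower number (0.29 log units; within the scatter) from compound 2 to compound 4; the limit leaves it open whether they differ Compound 1 gives only a limit and not a number, so the true size of its step stays unknown, and the pair of steps shows neither that the change transfers nor that it fails to: the limit of > 200000 nM in this assay, at which 1 of the 4 values shown sits.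

The compounds shown leave open how a longer chain or a benzyl group in place of the isopropyl would read in this assay on either core. They also leave open what a methyl ester in place of the carboxylic acid would do, and whether a step beyond the scatter could appear on the larger core.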